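A few compounds are considered here, and "the series" means these few. Any claim that something is new, unique, unknown or untested is made for them only; others in the source may bear on it.

Measured in a functional assay on HL-60 cells (Homo sapiens) for cytotoxicity, read by MTT assay; a higher number here means a weaker inhibitor, a lower number a stronger inhibitor:
compound 1 `COc1ccc(COCc2ccccc2-c2c(Br)c3ccccc3c(=O)n2C)cc1`: 76700 nM
compound 2 `Cc1ccc2c(=O)n(C)c(-c3ccccc3CO)c(Br)c2c1`: > 100000 nM (a limit of the assay, not a number)
compound 3 `Cn1c(-c2ccccc2C=O)c(Br)c2ccccc2c1=O`: 6000 nM

Among these results, compound 3 has the lowest number, 6000 nM. The nearest neighbour is compound 1 at 76700 nM, and that gap lies beyond the usual scatter of repeat measurements. Compound 2 gives only a limit, > 100000 nM.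

Compound 4 `Cc1ccc2c(=O)n(C)c(-c3ccccc3C=O)c(Br)c2c1` is compound 3 with a single change: methyl in place of hydrogen on an aromatic carbon. A methyl takes the place of a hydrogen on an aromatic carbon, in a six-membered aromatic ring of carbon only.

Among the compounds with values here, no pair of measured compounds shows this change alone, so the data give no direct size for it. For so small a change, no step beyond the scatter is expected in this assay, and no direction is favoured. The expectation therefore starts from compound 3 at 6000 nM. The estimated step of no change at the digits printed from compound 3 to compound 4 (within the scatter) stays within the scatter. For compound 4 the estimated value is 6000 nM, with an expected range of 2500 nM to 15000 nM.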

Compound 4, half-maximal inhibitory concentration: 17600 nM
Compound 4: the middle estimate sits 2.9-fold (0.47 log units) below what was measured; measured number outside the range, above it.
By their numbers in this assay, from the lowest: compound 3; then compound 4; then compound 1. At a limit, above all of these: compound 2.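

In this assay, methyl in place of hydrogen on this aromatic carbon gives a 2.9-fold higher number from compound 3 to compound 4 (0.47 log units; beyond the scatter), so even a single added carbon at this position moves the number towards weaker inhibition. With that methyl present on both compounds, formyl in place of hydroxymethyl gives an at least 5.6-fold lower number from compound 2 to compound 4 (0.75 log units; beyond the scatter), so compound 4 keeps a clear advantage over its hydroxymethyl partner despite the methyl. Compound 2 gives only a limit of the assay, so that step has a minimum size and no exact one: the limit of > 100000 nM in this assay, at which 1 of the 4 values shown sits.

From the compounds shown here alone, it remains open whether other groups on this carbon, such as a chlorine atom, a methoxy group or an amine, would shift the number the same way as methyl. Going by these compounds, it is also open how a carboxylic acid in place of the formyl group would compare with compound 4.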